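The compounds below may be only part of what the source reports. "The series", "measured", "known", "first", "only" and "open" are said of these compounds alone.

Measured compounds:
compound 1, `O=c1cc(CSC(=S)N2CCCCC2)oc2cc(Cl)ccc12`, > 25000 nM
compound 2, `O=c1c(CSC(=S)N2CCCCC2)coc2cc(Cl)ccc12`, 380 nM

The pair was tested in a functional assay on MCF7 cells (Homo sapiens) for antiproliferative activity, read by MTT assay, with a stated time of 72 h; on this read-out higher numbers stand for weaker inhibition and lower numbers for stronger inhibition. Compound 1 returned only a limit, > 25000 nM, so no number is known for it; the value sits at the upper boundary of the assay, (the limit of > 25000 nM in this assay, at which 1 of the 2 values shown sits). Compound 2, which carries the same dithiocarbamate side chain on the shared core but at a different position, gives a measured number, 380 nM, in this assay. Within the data shown here, no step between the two is counted, and the two structures are not compared further here.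

Compound 3, `CCN(CC)C(=S)SCc1cc(=O)c2ccc(Cl)cc2o1`, differs from compound 1 in one place, (diethylamino in place of piperidin-1-yl on a thiocarbonyl carbon). Compound 1 itself stands at the limit of this assay, with no measured number to move from. With so small a change at the thiocarbonyl carbon, the step from compound 1 to compound 3 is expected to be none beyond the usual scatter, a step that the limit leaves unreadable from compound 1 to compound 3, and compound 3 is most likely to return a limit as well. Compound 3 is therefore estimated at 30000 nM, within a range from 8000 nM to 120000 nM.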

Compound 3, half-maximal inhibitory concentration: > 25000 nM
Compound 3 ended at the assay's limit; the forecaster's own chance of this, stated with the estimate: 70%; the middle value does not contradict the limit.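

Among these compounds, compound 3 gives only a limit, > 25000 nM, in this assay, and compound 1 is also a limit, so no step between compound 1 and compound 3 can be read: the limit of > 25000 nM in this assay, at which 2 of the 3 values shown sit. The compounds shown leave open whether diethylamino in place of piperidin-1-yl on a thiocarbonyl carbon makes any difference in this assay.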